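A Smaller Aromatic Group in Place of the Bicycle

A few compounds are considered here, and "the series" means these few. Any claim that something is new, unique, unknown or untested is made for them only; others in the source may bear on it.

Compound 1 `Cn1c(=O)c(S(=O)(=O)c2ccc(F)cc2F)cc2cnc(Nc3ccc4cccc(O)c4n3)nc21`: 5000 nM
Compound 2 `Cn1c(=O)c(S(=O)(=O)c2ccc(F)cc2F)cc2cnc(Nc3ccc4sccc4c3)nc21`: 500 nM
Compound 3 `Cn1c(=O)c(S(=O)(=O)c2ccc(F)cc2F)cc2cnc(Nc3ccc4c(c3)CC(=O)N4)nc21`: 100000 nM

In a functional assay on DU-145 cells (Homo sapiens) for inhibition, read by trypan blue exclusion, with a stated time of 72 h (a lower number here means a stronger inhibitor, a higher number a weaker inhibitor), compound 3 gives 100000 nM, the highest of the three numbers: the steps of a 20-fold higher number from compound 1 to compound 3 (1.30 log units; beyond the scatter) and a 200-fold higher number from compound 2 to compound 3 (2.30 log units; beyond the scatter) both lie beyond the scatter. Compound 4 `Cn1c(=O)c(S(=O)(=O)c2ccc(F)cc2F)cc2cnc(Nc3ccncn3)nc21` carries the change (a group of 6 heavy atoms (4 carbon, 2 nitrogen; one six-membered aromatic ring with 2 hetero atoms) in place of a group of 10 heavy atoms (8 carbon, 1 nitrogen, 1 oxygen; one five-membered non-aromatic ring with 1 hetero atom, one six-membered aromatic ring of carbon only), on a nitrogen on an aromatic ring). The two measured steps bear on it directly, since each exchanges the same departing group for an aromatic group and, read towards compound 3, each raised the number by a large amount. Pyrimidin-4-yl is aromatic as well, though smaller than 8-hydroxyquinolin-2-yl or 1-benzothiophen-5-yl, so a lower number is expected for compound 4, probably of smaller size than those steps. Compound 4 is estimated at 10000 nM (range 2000 nM to 60000 nM), a step of a 10-fold lower number from compound 3 to compound 4 (1.00 log units; beyond the scatter).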

Compound 4, half-maximal inhibitory concentration: 50000 nM
For compound 4 the middle estimate is 5.0-fold (0.70 log units) below the measured one; low and high end bracket the measured number.
By their numbers in this assay, from the lowest: compound 2; then compound 1; then compounds 4 and 3 (each within the scatter of the next).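

Pyrimidin-4-yl on this nitrogen cannot be told apart from the non-aromatic-ring bicycle it replaces, with a 2.0-fold lower number from compound 3 to compound 4 (0.30 log units; within the scatter) in this assay. An aromatic group alone is therefore not enough here: the single ring stays well away from both aromatic bicycles, with a 10-fold higher number from compound 1 to compound 4 (1.00 log units; beyond the scatter) and a 100-fold higher number from compound 2 to compound 4 (2.00 log units; beyond the scatter). No measurement at hand accounts for these steps.

On these data alone, whether a plain phenyl group, or a phenyl carrying an amine, would fall with the two aromatic bicycles or with pyrimidin-4-yl stays open.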